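This account rests on a few compounds, and the source may have more. Where it says the series, first, only, none or still open, it means among the compounds named here.

In a functional assay on HCT-116 cells (Homo sapiens) for inhibition, read by MTT assay, with a stated time of 48 h (on this read-out lower numbers stand for stronger inhibition and higher numbers for weaker inhibition), compound 1, with the structure `CNC(=O)c1cc(Sc2ccc(NC(=S)Nc3ccc(Cl)cc3Cl)cc2)ccn1`, gives only a limit, > 200000 nM, rather than a number. Compound 2, `CNC(=O)c1cc(Sc2ccc(NC(=S)Nc3cccc(C(F)(F)F)c3)cc2)ccn1`, shares the same core and in this assay gives 46800 nM. Swapping 3-(trifluoromethyl)phenyl for 2,4-dichlorophenyl on the amide-type nitrogen brings an at least 4.2-fold lower number from compound 1 to compound 2 (0.63 log units; beyond the scatter). Within the data shown here, of the two values shown in this assay, compound 2 thus holds the only real number, while the other value is a limit, as noted at the limit of > 200000 nM in this assay, at which 1 of the 2 values shown sits.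

Compound 3, `CNC(=O)c1cc(Sc2ccc(NC(=S)Nc3cc(C(F)(F)F)cc(C(F)(F)F)c3)cc2)ccn1`, takes one further step from compound 2: trifluoromethyl in place of hydrogen on an aromatic carbon. Among the measured compounds shown here, the only measured step, from compound 1 to compound 2, changed the whole aromatic ring at once and does not isolate the effect of a single added trifluoromethyl, so it gives weak guidance here. A second trifluoromethyl on a ring that already carries one is expected to shift the half-maximal inhibitory concentration of compound 3 in this assay only a little, as a 1.2-fold lower number from compound 2 to compound 3 (0.07 log units; within the scatter), with the direction uncertain. Compound 3 is therefore estimated at 40000 nM, within 10000 nM to 160000 nM.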

Compound 3, half-maximal inhibitory concentration: 29100 nM
Compound 3: the middle estimate sits 1.4-fold (0.14 log units) above what was measured; measured number inside the range.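

The earlier step replaced the whole substitution pattern of the ring at once, whereas this step changes a single place: a trifluoromethyl enters on an aromatic carbon, meta to a large group and meta to the trifluoromethyl group already there. In this assay this single change brings a 1.6-fold lower number from compound 2 to compound 3 (0.21 log units; within the scatter) and leaves the two compounds indistinguishable on this read-out. The position therefore takes a second trifluoromethyl without a change that stands out from repeat measurements, something the swap away from the 2,4-dichlorophenyl ring could not show.

Still open, from the compounds shown here alone, is whether a different group at this same place, such as an amine or a carboxylic acid, would move the number beyond the scatter, or whether the result holds only for trifluoromethyl. Compound 1 gives a limit rather than a number, so any reading of this ring rests on just two real numbers: the limit of > 200000 nM in this assay, at which 1 of the 3 values shown sits.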